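Halogen swap on the aryl ring of compound 2

A few compounds are considered here, and "the series" means these few. Any claim that something is new, unique, unknown or untested is made for them only; others in the source may bear on it.

Among the measured compounds shown here, compound 2 `Cn1c(CN2CCC(c3ccc(Cl)cc3)CC2)nc2ccccc21` gives 79.4 nM in an assay on CHO cells with metabotropic glutamate receptor 2 (Homo sapiens) as the target, read by FLIPR (on this read-out lower numbers stand for an effect already at smaller amounts and higher numbers for an effect only at larger amounts of compound), and holds the lowest of the three numbers measured so far. Compound 3 `CCn1c(CN2CCN(c3ncc(Cl)cn3)CC2)nc2ccccc21` gives 158 nM in this assay; this value and that of compound 2 lie within the scatter of each other. Compound 1 `Cn1c(CN2CCC(c3ccccc3)CC2)nc2ccccc21` gives 200 nM in this assay. For the measured compounds named here, the one measured single-place step is a 2.5-fold lower number from compound 1 to compound 2 (0.40 log units; beyond the scatter); it concerns the chloro alone.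

Compound 4 `Cn1c(CN2CCC(c3ccccc3F)CC2)nc2ccccc21` differs from compound 2 in one place: 2-fluorophenyl in place of 4-chlorophenyl on a saturated ring carbon. Going by the values given here, the change takes away the chloro that accompanied the modest gain in the step just named, and brings in a fluorine at a place for which no measured pair exists. Among the compounds with values here, the measured step therefore bears only on the loss side; the 2-fluorophenyl has no counterpart among the measured compounds. The plainest reading is that compound 4 falls back toward the number of compound 1, 200 nM, with a wider range than usual, since the fluorine side of the change is uncovered by any measured step.

Compound 4 is accordingly expected near 180 nM in this assay, within a range of 70 nM to 450 nM. This corresponds to an expected step of a 2.3-fold higher number from compound 2 to compound 4 (0.36 log units; beyond the scatter).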

Compound 4, half-maximal effective concentration: 126 nM
Compound 4: the middle estimate sits 1.4-fold (0.15 log units) above what was measured, within the range that was stated.
By their numbers in this assay, from the lowest: compounds 2, 4, 3 and 1 (each within the scatter of the next, the first and the last beyond it).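

Replacing 4-chlorophenyl with 2-fluorophenyl on the saturated ring carbon gives a 1.6-fold higher number from compound 2 to compound 4 (0.20 log units; within the scatter), and adding the fluoro group alone to unsubstituted phenyl gives a 1.6-fold lower number from compound 1 to compound 4 (0.20 log units; within the scatter). In this assay compound 4 therefore cannot be told apart from either of these two compounds, even though the chloro step, a 2.5-fold lower number from compound 1 to compound 2 (0.40 log units; beyond the scatter), lies beyond the scatter; at this place, the 2-fluorophenyl group reads neither as a clear loss against 4-chlorophenyl nor as a clear gain over unsubstituted phenyl. Nothing available explains any of these steps.

The 2-fluorophenyl group differs from 4-chlorophenyl in both the halogen and its place on the aromatic ring, so the compounds shown leave open which of the two matters, if either does. Also open, on these data alone, is how a methoxy group, a nitrile or a trifluoromethyl group on that aromatic ring would read in this assay, and whether a second halogen on the ring would carry the number of compound 4 beyond the scatter of compound 1.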